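The compounds below may be only part of what the source reports. "The series", "measured", "known", "first", "only" and "open" are said of these compounds alone.

Measured so far in a functional assay on MCF7 cells (Homo sapiens) for antiproliferative activity, with a stated time of 72 h; a higher number here means a weaker inhibitor, a lower number a stronger inhibitor:
Compound 1, `Cn1c(N2N=C(c3ccccc3)CC2c2ccccc2)nc(-c2ccccc2)c(C#N)c1=O`: 35400 nM
Compound 2, `Cn1c(N2N=C(c3ccccc3)CC2c2ccc(Cl)cc2)nc(-c2ccccc2)c(C#N)c1=O`: 3280 nM
Compound 3, `COc1ccc(C2CC(c3ccccc3)=NN2c2nc(-c3ccccc3)c(C#N)c(=O)n2C)cc1`: 18000 nM

Among these three, compound 3 has the second highest number. Its nearest neighbour is compound 1, and the step of a 2.0-fold lower number from compound 1 to compound 3 (0.29 log units; within the scatter) lies within the scatter. Its furthest neighbour is compound 2, and the step of a 5.5-fold higher number from compound 2 to compound 3 (0.74 log units; beyond the scatter) lies beyond it.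

Compound 4, `COc1ccc(C2=NN(c3nc(-c4ccccc4)c(C#N)c(=O)n3C)C(c3ccc(OC)cc3)C2)cc1`, differs from compound 3 in one place: methoxy in place of hydrogen on an aromatic carbon. Within the data shown here, the one measured step of the same kind is a 2.0-fold lower number from compound 1 to compound 3 (0.29 log units; within the scatter), which stayed within the scatter, so for compound 4 no step beyond the scatter is expected in this assay. Compound 4 is therefore estimated at 14000 nM, expected between 5000 nM and 40000 nM, which means an expected 1.3-fold lower number from compound 3 to compound 4 (0.11 log units; within the scatter).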

Compound 4, half-maximal inhibitory concentration: 127000 nM
Compound 4: the middle estimate sits 9.1-fold (0.96 log units) below what was measured; measured number above the stated range.
By their numbers in this assay, from the lowest: compound 2; then compounds 3 and 1 (each within the scatter of the next); then compound 4.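

In this assay, the phenyl to 4-methoxyphenyl change is not neutral on this second phenyl ring: a 7.1-fold higher number from compound 3 to compound 4 (0.85 log units; beyond the scatter), making compound 4 a weaker inhibitor. The same kind of change on the other phenyl ring stayed within the scatter, a 2.0-fold lower number from compound 1 to compound 3 (0.29 log units; within the scatter), so its outcome depends on which ring carries the methoxy. Nothing available here explains this difference. Going by these compounds, it remains open whether a hydroxyl, a fluorine or an amine at this ring position would also weaken inhibition, or whether this is specific to methoxy.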